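The source may report more compounds than this note shows. Statements on the series, on what has been measured and on what is new or still open speak of the compounds shown alone.

Compound 1 `O=C1c2ccccc2C(=O)N1CNc1ccc(Cl)cc1` gives 8.52% in an assay on isolated protein for inhibition of ribosomal protein S6 kinase alpha-2 (Homo sapiens), read by fluorescence, with a stated time of 20 min, tested at 10 uM; a lower number here means less inhibition, a higher number more inhibition at the concentration tested (going by the name of the read-out).
Compound 2 `CCc1ccc(NCN2C(=O)c3ccccc3C2=O)cc1` gives 63% in this assay.
Compound 3 `CC(C)c1ccc(NCN2C(=O)c3ccccc3C2=O)cc1` gives 46.5% in this assay.

Compound 3 stands second highest of the three numbers in this assay: the step of a number 16.5 percentage points lower from compound 2 to compound 3 (beyond the scatter) separates it from the top, while a number 38 percentage points higher from compound 1 to compound 3 (beyond the scatter) sets it well above the lowest. Compound 4 `COc1ccc(NCN2C(=O)c3ccccc3C2=O)cc1` differs from compound 3 by methoxy in place of isopropyl on an aromatic carbon. Among the compounds with values here, no measured step exchanges an alkyl for methoxy. The steps of a number 54.5 percentage points higher from compound 1 to compound 2 (beyond the scatter) and a number 38 percentage points higher from compound 1 to compound 3 (beyond the scatter) show that swapping chloro for an alkyl raised inhibition greatly, whereas a number 16.5 percentage points lower from compound 2 to compound 3 (beyond the scatter) shows a modest loss on enlarging the alkyl. Methoxy is neither chloro nor alkyl, so a step of moderate size downward is expected for compound 4, a number 11.5 percentage points lower from compound 3 to compound 4 (beyond the scatter), with wide uncertainty. Compound 4 is estimated at 35%, expected to fall between 10% and 62%.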

Compound 4, a percentage reported as inhibition, at one concentration (the size of the read-out at that concentration, not a potency): 97.2%
Compound 4: the middle estimate sits 62.2 percentage points below what was measured; measured number outside the range, above it.
By their numbers in this assay, from the lowest: compound 1; then compound 3; then compound 2; then compound 4.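

On the aromatic carbon para to a large group, methoxy gives more inhibition in this assay than any group seen there before (a number 50.7 percentage points higher from compound 3 to compound 4 (beyond the scatter); a number 34.2 percentage points higher from compound 2 to compound 4 (beyond the scatter); a number 88.7 percentage points higher from compound 1 to compound 4 (beyond the scatter)). High inhibition at this position therefore does not require an alkyl group, and the earlier gain from chloro to alkyl did not mark the upper end of what this position allows. Nothing available explains this result.

The compounds shown leave open whether the longer ethoxy keeps this level of inhibition. They also do not show how hydroxy or an amine would behave at this position.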